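Exchanging a Methoxyphenoxy Arm for a Furan Ring

The source may hold more compounds than are shown below. What is called first, only, known or untested is meant among the compounds shown, and "the series" means these compounds.

Measured compounds:
compound 1, `Cc1ccccc1-n1nc(C)c2c1NC(=O)[C@H](C)S[C@@H]2c1ccc(-c2cc3ccccc3o2)cc1`, 1500 nM
compound 2, `Cc1ccccc1-n1nc(C)c2c1NC(=O)[C@H](C)S[C@@H]2c1ccc(-c2ccsc2)cc1`, 1400 nM
compound 3, `COc1ccc(Oc2ccc([C@H]3S[C@@H](C)C(=O)Nc4c3c(C)nn4-c3ccccc3C)cc2)cc1`, 2200 nM

In an assay on isolated protein for agonist activity at Bile acid receptor (Homo sapiens), read by AlphaScreen, with a stated time of 30 min (on this read-out higher numbers stand for an effect only at larger amounts of compound and lower numbers for an effect already at smaller amounts), compound 3 gives 2200 nM. This is the highest of the three numbers, but the two steps that lead to it are small, a 1.5-fold higher number from compound 1 to compound 3 (0.17 log units; within the scatter) and a 1.6-fold higher number from compound 2 to compound 3 (0.20 log units; within the scatter), so compound 3 stands level with both other measured compounds within the scatter. Compound 4, `Cc1ccccc1-n1nc(C)c2c1NC(=O)[C@H](C)S[C@@H]2c1ccc(-c2ccco2)cc1`, has not yet been measured. It differs from compound 3 in one place: furan-2-yl in place of 4-methoxyphenoxy on an aromatic carbon. For the measured compounds named here, the steps that bear on this change are those that put 4-methoxyphenoxy in place of a small aromatic ring, a 1.5-fold higher number from compound 1 to compound 3 (0.17 log units; within the scatter) and a 1.6-fold higher number from compound 2 to compound 3 (0.20 log units; within the scatter), and the step among small aromatic rings, a 1.1-fold lower number from compound 1 to compound 2 (0.03 log units; within the scatter); all three lie within the scatter. Going the other way, from 4-methoxyphenoxy back to a small aromatic ring, the account therefore expects no step in this assay beyond the scatter for compound 4, at most a slight move toward lower numbers, a 1.5-fold lower number from compound 3 to compound 4 (0.17 log units; within the scatter). The estimate for compound 4 is 1500 nM, with a range from 700 nM to 3500 nM.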

Compound 4, half-maximal effective concentration: 3600 nM
For compound 4 the middle estimate is 2.4-fold (0.38 log units) below the measured one, outside the stated range (above it).
By their numbers in this assay, from the lowest: compounds 2, 1, 3 and 4 (each within the scatter of the next, the first and the last beyond it).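

In this assay the aromatic carbon para to a large group now gives its first steps beyond the scatter, namely a 2.6-fold higher number from compound 2 to compound 4 (0.41 log units; beyond the scatter) and a 2.4-fold higher number from compound 1 to compound 4 (0.38 log units; beyond the scatter) and both are modest. Set against 4-methoxyphenoxy, furan-2-yl gives only a 1.6-fold higher number from compound 3 to compound 4 (0.21 log units; within the scatter) and so stands level with that group despite having fewer heavy atoms. The aromatic rings at this position therefore do not all read alike: furan-2-yl separates from thiophen-3-yl and 1-benzofuran-2-yl, while 4-methoxyphenoxy lies within the scatter of all three.

The compounds shown leave open how an amine, a carboxylic acid or a longer chain would read on this carbon. Nothing given here accounts for the separation of furan-2-yl from the other two rings.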